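A Trifluoromethyl Group Changes Place on a Phenyl Ring

This account rests on a few compounds, and the source may have more. Where it says the series, first, only, none or still open, it means among the compounds named here.

Of the compounds shown here, three that share one core have been tested so far. In a functional assay on HeLa cells (Homo sapiens) for inhibition, read by MTT assay, with a stated time of 72 h (on this read-out higher numbers stand for weaker inhibition and lower numbers for stronger inhibition), compound 1 `COc1cc(NC(C)CCCNC(=O)Nc2cccc(Cl)c2)c2ncccc2c1` gives 17000 nM and compound 2 `COc1cc(NC(C)CCCNC(=O)NNC(=O)Nc2ccc(C(F)(F)F)cc2)c2ncccc2c1` gives 15000 nM as its value, and these two numbers lie within the usual scatter of each other. Compound 3 `COc1cc(NC(C)CCCNC(=O)Nc2cc(C(F)(F)F)cc(C(F)(F)F)c2)c2ncccc2c1` gives 3100 nM as its value, lower than the number for compound 2 by more than the scatter, which means stronger inhibition. Compound 2 therefore stands level with compound 1 and clearly short of compound 3.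

Compound 4 `COc1cc(NC(C)CCCNC(=O)NNC(=O)Nc2cccc(C(F)(F)F)c2)c2ncccc2c1` has no measured value yet. It differs from compound 2 at a single place, with 3-(trifluoromethyl)phenyl in place of 4-(trifluoromethyl)phenyl on an amide-type nitrogen, and 3-(trifluoromethyl)phenyl in place of 4-(trifluoromethyl)phenyl on an amide-type nitrogen sums up that change. Among the measured compounds shown here, no measured pair shows this change alone, so the expectation rests on little. Compound 3 at 3100 nM also carries trifluoromethyl, but it differs from compound 2 in more than one place and offers only a slight lean toward a lower number. The expected step in this assay is a 1.4-fold lower number from compound 2 to compound 4 (0.13 log units; within the scatter) as an estimate, small and not beyond the scatter. For compound 4 the estimated value is 11000 nM with an expected range from 5000 nM to 25000 nM in this measurement.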

Compound 4, half-maximal inhibitory concentration: 4900 nM
Compound 4: the middle estimate sits 2.2-fold (0.35 log units) above what was measured, and the stated range ends above it.
By their numbers in this assay, from the lowest: compounds 3 and 4 (each within the scatter of the next); then compounds 2 and 1 (each within the scatter of the next).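

Where the trifluoromethyl group sits on the phenyl ring matters in this series: in this assay the change from 4-(trifluoromethyl)phenyl to 3-(trifluoromethyl)phenyl on the amide-type nitrogen gives a 3.1-fold lower number from compound 2 to compound 4 (0.49 log units; beyond the scatter) and this step lies beyond the usual scatter. Among the compounds shown here, the two groups hold the same atoms and the same ring, so no atom is gained or lost, and the arrangement of those atoms alone is enough to move the number, something no earlier pair of compounds could show. Nothing measured here explains why the two arrangements differ.

This is a single pair, so it cannot tell whether the same change would give a similar step with another core or another linker, or in other cells. It also leaves open what other groups would do on the phenyl ring in place of trifluoromethyl, such as a nitrile, an amine or a carboxylic acid, and whether any of them would lower the number further.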